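The source may hold more compounds than are shown below. What is called first, only, known or untested is meant among the compounds shown, and "the series" means these compounds.

Three compounds share one core in which a urea-bearing ring carries a second aryl group on a ring nitrogen. Compound 1 `COc1cc(NC(=O)Nc2cc(Nc3ccc(OC)c(C)c3)ncn2)cc(OC)c1` gives 48.3% in a functional assay on HCC827 cells (Homo sapiens) for inhibition, read by MTT assay, with a stated time of 48 h, tested at 10 uM; a higher number here means more inhibition at the concentration tested (going by the name of the read-out), a lower number less inhibition. Compound 2 `Cc1ccc(Nc2cc(NC(=O)Nc3c(Cl)cccc3Cl)ncn2)cc1F` gives 85.3%, and compound 3 `O=C(Nc1cc(Nc2ccc(F)c(Cl)c2)ncn1)Nc1c(Cl)cccc1Cl` gives 53.7%. Compound 3 stands second highest of the three: it sits close to compound 1, within the usual scatter, and clearly under compound 2, since a number 31.6 percentage points lower from compound 2 to compound 3 (beyond the scatter) — a large drop that came from swapping one aryl group for another on the same nitrogen.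

Compound 4 `COc1ccc(Nc2cc(NC(=O)Nc3c(Cl)cccc3Cl)ncn2)cc1C` is the next step from compound 3. The change is 4-methoxy-3-methylphenyl in place of 3-chloro-4-fluorophenyl on a nitrogen on an aromatic ring. Within the data shown here, the one measured step that bears on it is the step from compound 2 to compound 3, which shows that exchanging the aryl group at this position can move the read-out by a large amount in either direction. Compound 1 carries the same 4-methoxy-3-methylphenyl group that enters here, though with a different urea aryl, and it sits near compound 3. On that basis compound 4 is expected to show a number 1.3 percentage points higher from compound 3 to compound 4 (within the scatter), a step not beyond the scatter. The estimate for compound 4 is 55%, with a range from 35% to 78%.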

Compound 4, a percentage reported as inhibition, at one concentration (the size of the read-out at that concentration, not a potency): 63.1%
Compound 4: the middle estimate sits 8.1 percentage points below what was measured; low and high end bracket the measured number.
By their numbers in this assay, from the lowest: compounds 1, 3 and 4 (each within the scatter of the next, the first and the last beyond it); then compound 2.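

In this assay the swap at this nitrogen gives a number 9.4 percentage points higher from compound 3 to compound 4 (within the scatter) and so cannot be told apart from no change, which means that 3-chloro-4-fluorophenyl and 4-methoxy-3-methylphenyl, two quite different sets of substituents, give readings within the scatter of each other when the 2,6-dichlorophenyl urea is kept. Not every aryl group is equal here, however: the data show a number 22.2 percentage points lower from compound 2 to compound 4 (beyond the scatter) as well as the earlier drop to compound 3, so 3-fluoro-4-methylphenyl stands clearly above both of the other groups tried with this urea. The other end of the molecule also counts, since with 4-methoxy-3-methylphenyl held fixed, putting 2,6-dichlorophenyl in place of 3,5-dimethoxyphenyl on the amide-type nitrogen gives a number 14.8 percentage points higher from compound 1 to compound 4 (beyond the scatter) and is the only step shown at that place.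

Nothing available explains the size of any of these steps. On these data alone, it also stays open whether a dimethylamino group or a carboxylic acid on this aryl ring, or an ethyl or longer chain in place of the methyl of 3-fluoro-4-methylphenyl, would keep the reading of compound 2.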